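Fluoro for Chloro on a Second Core

The source may hold more compounds than are shown below. What is called first, only, known or untested is meant among the compounds shown, and "the series" means these compounds.

Compound 2 `Cc1cc(C)c2c(O)cc(-c3cccc(Cl)c3)nc2n1` and compound 1 `Cc1cc(C)c2c(O)cc(-c3cccc(F)c3)nc2n1` share one core and differ only by the change (fluoro in place of chloro on an aromatic carbon). In a functional assay on U-251 cells (Homo sapiens) for antiproliferative activity (a lower number here means a stronger inhibitor of growth, a higher number a weaker inhibitor of growth), compound 2 gives 295 nM, and compound 1 gives 64.6 nM, so that the step is a 4.6-fold lower number from compound 2 to compound 1 (0.66 log units; beyond the scatter). Compound 3 `Cc1cnc2[nH]c(-c3cccc(Cl)c3)cc(=O)c2c1` carries a different core, and the difference between the two cores is not broken down here; in this assay compound 3 gives 69.2 nM. Compound 4 `Cc1cnc2[nH]c(-c3cccc(F)c3)cc(=O)c2c1` arises from compound 3 by fluoro in place of chloro on an aromatic carbon, the same change as before, at the same kind of place. Going by the values given here, compound 4 is expected to show a step of a 2.8-fold lower number from compound 3 to compound 4 (0.44 log units; beyond the scatter), resting on the single earlier step of a 4.6-fold lower number from compound 2 to compound 1 (0.66 log units; beyond the scatter) and tempered, since the core differs and no step for this change on the core of compound 3 has been measured. Compound 4 is estimated at 25 nM, likely between 8 nM and 80 nM.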

Compound 4, concentration for 50% growth inhibition: 40.7 nM
Compound 4: the middle estimate sits 1.6-fold (0.21 log units) below what was measured; the range from low to high includes it.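

In this assay fluoro in place of chloro on the core of compound 3 gives a 1.7-fold lower number from compound 3 to compound 4 (0.23 log units; within the scatter) and so leaves the two compounds indistinguishable on this core. The step did not keep its earlier size on the second core: the same change on two cores in this assay, a 4.6-fold lower number (0.66 log units; beyond the scatter) from compound 2 to compound 1 and a 1.7-fold lower number (0.23 log units; within the scatter) from compound 3 to compound 4, 2.7-fold (0.43 log units) apart, beyond the scatter of two such steps. The change therefore cannot be carried unaltered from one of these cores to the other, but with a single pair on each core this does not show why the steps differ or what the change would do on any further core.

The compounds shown leave open how a methoxy group, a nitrile or an amine would fare at the same aromatic carbon on either core.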